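The compounds below may be only part of what the source reports. "The series", "measured", "known", "first", "only" and "open" are said of these compounds alone.

Compound 3 `CN(C)C1(Cc2ccccc2)CCN(c2cc(C(F)(F)F)ccc2CNC(=O)Nc2cccc3[nH]c(=O)ccc23)CC1` gives 30.6 nM in an assay on CHO cells for antagonist activity at transient receptor potential cation channel subfamily V member 1 (Homo sapiens), read by scintillation counting, with a stated time of 5 min, in the presence of a further agent that is not named here (a higher number here means that more compound is needed for the effect, a lower number that less compound is needed), the second highest of the three numbers seen so far. Compound 1 `CN(C)C1(Cc2ccccc2)CCN(c2cc(C(F)(F)F)ccc2CNC(=O)Nc2ccc(CNS(C)(=O)=O)c(F)c2)CC1` gives 25 nM, within the scatter of that, while compound 2 `CN(C)C1(Cc2ccccc2)CCN(c2cc(C(F)(F)F)ccc2CNC(=O)Nc2ccc(CNS(N)(=O)=O)c(F)c2)CC1` gives 120 nM, beyond it. Compound 4 `CN(C)C1(Cc2ccccc2)CCN(c2cc(C(F)(F)F)ccc2CNC(=O)Nc2cccc3cnccc23)CC1` differs from compound 3 by a group of 10 heavy atoms (9 carbon, 1 nitrogen; one six-membered aromatic ring of carbon only, one six-membered aromatic ring with 1 hetero atom) in place of a group of 11 heavy atoms (9 carbon, 1 nitrogen, 1 oxygen; one six-membered aromatic ring of carbon only, one six-membered aromatic ring with 1 hetero atom), on an amide-type nitrogen. For the measured compounds named here, the only measured step, a 4.8-fold higher number from compound 1 to compound 2 (0.68 log units; beyond the scatter), concerns a substituent on a sulfonyl sulfur in another part of the shared core and does not touch this group, so no measured step bears directly on the change. A moderate step toward a higher number is therefore expected, with wide uncertainty. Compound 4 is estimated at 55 nM, within a range from 15 nM to 200 nM. That estimate means an expected step of a 1.8-fold higher number from compound 3 to compound 4 (0.25 log units; within the scatter).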

Compound 4, half-maximal effective concentration: 8.8 nM
Estimate against measurement, compound 4: 6.3-fold (0.80 log units) above; the measured number lies below the stated range.
By their numbers in this assay, from the lowest: compound 4; then compounds 1 and 3 (each within the scatter of the next); then compound 2.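

In this assay, for the compounds shown here, the group on the amide-type nitrogen turns out to matter: isoquinolin-5-yl brings a 3.5-fold lower number from compound 3 to compound 4 (0.54 log units; beyond the scatter) and this is the first step measured at this place. The entering group has no hydrogen-bond donor and no double bond outside aromatic rings, so a low number here needs neither feature of the group that leaves. Nothing available explains the step. The compounds shown leave open which of the two differences carries the change, and whether the ring nitrogen matters, as a naphthalen-1-yl group, with carbon only in both rings, would show.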